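A few compounds are considered here, and "the series" means these few. Any claim that something is new, unique, unknown or untested is made for them only; others in the source may bear on it.

Measured compounds:

compound 1, `C/C(=N\O)C(=O)NCCCCCC(=O)Nc1ccccc1`: > 100000 nM in a functional assay on HCT-116 cells (Homo sapiens) for inhibition, read by colorimetric assay, with a stated time of 3 days (on this read-out lower numbers stand for stronger inhibition and higher numbers for weaker inhibition), a limit of the assay rather than a number
compound 2, `NC(=O)C(=O)NCCCCCC(=O)Nc1ccccc1`: > 100000 nM in this assay, again a limit
compound 3, `NC(=O)C(=O)NCCCCC(=O)Nc1ccccc1`: > 100000 nM in this assay, again a limit

All three compounds share an anilide end and a chain that carries a second amide; none of them reaches a readable inhibition value in this assay. Compound 1 differs from compound 2 by a group of 4 heavy atoms (2 carbon, 1 nitrogen, 1 oxygen; no ring) in place of a group of 3 heavy atoms (1 carbon, 1 nitrogen, 1 oxygen; no ring), on a carbonyl carbon. The step from compound 2 to compound 1 is a step that the two limits leave unreadable from compound 2 to compound 1, which rests on (the limit of > 100000 nM in this assay, at which 3 of the 3 values shown sit). Compound 3 differs from compound 2 in the length of the chain, but the difference between the two cores is not broken down here.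

The unmeasured compound 4, `C/C(=N\O)C(=O)NCCCCC(=O)Nc1ccccc1`, differs from compound 3 by a group of 4 heavy atoms (2 carbon, 1 nitrogen, 1 oxygen; no ring) in place of a group of 3 heavy atoms (1 carbon, 1 nitrogen, 1 oxygen; no ring), on a carbonyl carbon. Among the measured compounds shown here, this is the same change as the one from compound 2 to compound 1, at the same place, on a carbonyl carbon whose other neighbours are an amide-type nitrogen.

For compound 4 a step that the limit leaves unreadable from compound 3 to compound 4 is expected, on the strength of the unreadable step that the two limits leave unreadable from compound 2 to compound 1 and of the limit of > 100000 nM in this assay, at which 3 of the 3 values shown sit, which together give no sign that this change moves a compound out of the region where the assay reports only a limit. Compound 4 is accordingly estimated at 200000 nM, with a range from 50000 nM to 1000000 nM, and most likely the assay will again return only a limit for it.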

Compound 4, half-maximal inhibitory concentration: > 100000 nM
Compound 4 gave a limit, no number; the forecaster's own chance of this, stated with the estimate: 85%; the middle value lies beyond the limit too.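

No new step can be read from compound 3 to compound 4, since both compounds return only a limit of the assay and not a number: the limit of > 100000 nM in this assay, at which 4 of the 4 values shown sit.

The compounds shown leave open whether the group on the carbonyl carbon or the length of the chain has any bearing on inhibition in this assay, where none of them gives a readable value.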